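This account rests on a few compounds, and the source may have more. Where it says the series, first, only, none or still open, it means among the compounds named here.

Compound 1 `CCOC(=O)CCCCCOc1cccc(CN(C(=O)c2ccc(-c3cccc(NC(C)=O)c3)cc2)C(C)C)c1` gives > 26000 nM in an ADME assay on HEK293 cells (Homo sapiens) for cytotoxicity, read by CellTiter-Glo and resazurin assay, with a stated time of 72 h; on this read-out lower numbers stand for an effect already at smaller amounts and higher numbers for an effect only at larger amounts of compound.
Compound 2 `CCOC(=O)CCCCCOc1cccc(CN(C(=O)c2ccc(-c3cccc(OCC)c3)cc2)C(C)C)c1` gives > 22300 nM in this assay.
Compound 3 `CCOC(=O)CCCCCOc1cccc(CN(C(=O)c2ccc(-c3cccc(Cl)c3)cc2)C(C)C)c1` gives > 18400 nM in this assay.

Every one of these three values is a limit of the assay and not a measured number: each compound was tested up to a top amount without reaching a half-maximal effect. Compound 3 therefore stands at the limit of > 18400 nM in this assay, at which 1 of the 3 values shown sits, with the two other compounds likewise sitting at limits, at the limit of > 22300 nM in this assay, at which 1 of the 3 values shown sits, and (the limit of > 26000 nM in this assay, at which 1 of the 3 values shown sits). The three steps between measured compounds, a step that the two limits leave unreadable from compound 1 to compound 2, a step that the two limits leave unreadable from compound 1 to compound 3 and a step that the two limits leave unreadable from compound 2 to compound 3, are all unreadable in size, since a step between two limits cannot be measured. Among the measured compounds shown here, they show only that changing the group on the outer ring of the shared core did not bring any of the three compounds below its limit.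

The move to compound 4 `CCOC(=O)CCCCCOc1cccc(CN(C(=O)c2ccc(Br)cc2)C(C)C)c1` is larger than any of those: bromo in place of 3-chlorophenyl on an aromatic carbon. For the measured compounds named here, no measured step bears on this change, so nothing indicates a direction. The step from compound 3 to compound 4 in this assay is expected to be a step that the limit leaves unreadable from compound 3 to compound 4. For compound 4 the estimate is 25000 nM, ranging from 9000 nM to 70000 nM, most likely reported again as a limit.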

Compound 4, half-maximal effective concentration: > 26000 nM
Compound 4: no number, only a limit; the forecaster's own chance of this, stated with the estimate: 75%; middle value at least 1.0-fold (0.01 log units) from the limit.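

Among the compounds shown here, compound 4 gives only a limit in this assay, as do compound 1, compound 2 and compound 3, so no step between compound 4 and those three can be read. As far as these compounds go, the amount of any of these four compounds that would reach a half-maximal effect stays open.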